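Swapping pyridin-4-yl for 4-bromophenyl on compound 2

The source may report more compounds than this note shows. Statements on the series, on what has been measured and on what is new or still open speak of the compounds shown alone.

For the measured compounds named here, in an ADME assay for permeability, using PAMPA, with a stated time of 4 h, tested at 10 uM (on this read-out higher numbers stand for higher permeability and lower numbers for lower permeability), compound 2 (`O=C(CCCCN1CCCCC1)Nc1cc(-c2ccncc2)n[nH]1`) gives 2 10^-6 cm/s, the only exact number so far. Compound 1 (`COc1ccc(-c2cnc(NC(=O)CCCCN3CCCN(C(C)=O)CC3)[nH]2)cc1`) gives > 10 10^-6 cm/s, which is a limit of the assay. Compound 3 (`COc1ccc(-c2cc(NC(=O)CCCCN3CCC(C)CC3)[nH]n2)cc1`) gives > 10 10^-6 cm/s, also a limit. Compound 4 (`O=C(CCCCN1CCCCC1)Nc1cc(-c2ccc(Br)cc2)n[nH]1`) has 4-bromophenyl in place of pyridin-4-yl on an aromatic carbon. Going by the values given here, no measured pair isolates this change, so any forecast is loose. Compound 3, with its limit of > 10 10^-6 cm/s, also carries a six-membered aromatic ring of carbon only, so a rise beyond the scatter is expected in this assay. The expected change is a 4.5-fold higher number from compound 2 to compound 4 (0.65 log units; beyond the scatter). Compound 4 is estimated at 9 10^-6 cm/s, within an expected range of 4 10^-6 cm/s to 25 10^-6 cm/s.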

Compound 4, apparent permeability: > 10 10^-6 cm/s
Compound 4 gave a limit, no number; the forecaster's own chance of this, stated with the estimate: 45%; middle value at least 1.1-fold (0.04 log units) from the limit.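

In this assay, for the compounds shown here, this is the first measured pair that differs in one place only, and placing 4-bromophenyl instead of pyridin-4-yl on this aromatic carbon gives an at least 5.0-fold higher number from compound 2 to compound 4 (0.69 log units; beyond the scatter). As far as these compounds go, the value of compound 4 is a limit, not a number, so the step gives only a minimum and its true size stays unknown: the limit of > 10 10^-6 cm/s in this assay, at which 3 of the 4 values shown sit.

The compounds shown leave open whether the loss of the ring nitrogen or the arrival of the bromine accounts for the step. A plain phenyl group on this carbon would separate the two.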